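This account rests on a few compounds, and the source may have more. Where it says the series, first, only, none or still open, it means among the compounds named here.

Compound 1, `NCCOc1ccc(/C(=C(\CCCl)c2ccccc2)c2ccc(O)cc2)cc1`, gives 143 nM in an assay on isolated protein for inhibition of Aromatase (Homo sapiens), read by fluorescence, with a stated time of 30 min; on this read-out higher numbers stand for weaker inhibition and lower numbers for stronger inhibition.
Compound 2, `CCC/C(=C(/c1ccc(O)cc1)c1ccc(OCCN)cc1)c1ccccc1`, gives 261 nM in this assay.
Compound 3, `C/C(=C(/c1ccc(O)cc1)c1ccc(OCCN)cc1)c1ccccc1`, gives 337 nM in this assay.

Among these three, compound 3 has the highest number. Compound 2 lies nearest to it, with a 1.3-fold higher number from compound 2 to compound 3 (0.11 log units; within the scatter), and compound 1 lies furthest, with a 2.4-fold higher number from compound 1 to compound 3 (0.37 log units; beyond the scatter).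

Compound 4, `CC(C)/C(=C(/c1ccc(O)cc1)c1ccc(OCCN)cc1)c1ccccc1`, differs from compound 3 in one place: isopropyl in place of methyl on a double-bonded chain carbon bound to an aromatic carbon and a double-bonded chain carbon. The steps that speak to this change are those that alter the group on the saturated chain carbon bound to a double-bonded chain carbon, namely a 1.3-fold higher number from compound 2 to compound 3 (0.11 log units; within the scatter) and a 2.4-fold higher number from compound 1 to compound 3 (0.37 log units; beyond the scatter): taking carbon away there went with a higher number, once within the scatter and once modestly beyond it. Adding carbon in the shared core, in the form of an isopropyl in place of methyl, is therefore expected to give compound 4 a somewhat lower number, or a step that does not leave the scatter.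

Compound 4 is expected to give about 250 nM in this assay, between 110 nM and 550 nM. This estimate means an expected step of a 1.3-fold lower number from compound 3 to compound 4 (0.13 log units; within the scatter).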

Compound 4, half-maximal inhibitory concentration: 328 nM
For compound 4 the middle estimate is 1.3-fold (0.12 log units) below the measured one; low and high end bracket the measured number.
By their numbers in this assay, from the lowest: compounds 1, 2, 4 and 3 (each within the scatter of the next, the first and the last beyond it).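

Isopropyl in place of methyl, a larger group at this place, leaves the number in this assay unmoved (a 1.0-fold lower number from compound 3 to compound 4 (0.01 log units; within the scatter)), and isopropyl in place of propyl also gives no separable result (a 1.3-fold higher number from compound 2 to compound 4 (0.10 log units; within the scatter)). Isopropyl in place of 2-chloroethyl does leave the scatter, modestly (a 2.3-fold higher number from compound 1 to compound 4 (0.36 log units; beyond the scatter)), yet the matching step to the propyl compound stays inside it (a 1.8-fold higher number from compound 1 to compound 2 (0.26 log units; within the scatter)), so the chlorine-bearing chain is not cleanly set apart from the all-carbon groups. Nothing available here offers an explanation for this flat picture.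

Every group shown at this place is a small carbon chain, one of them carrying chlorine. As far as these compounds go, how an amine, a carboxylic acid, a phenyl ring or a longer chain such as hexyl would behave there remains open.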